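This account rests on a few compounds, and the source may have more. Where it says the series, first, only, none or still open, it means among the compounds named here.

Among the measured compounds shown here, in a functional assay on HCT-116 cells (Homo sapiens) for antiproliferative activity, read by MTT assay, with a stated time of 48 h (a higher number here means a weaker inhibitor, a lower number a stronger inhibitor), compound 1 (`COc1ccc(-c2c(Nc3cc(OC)c(OC)c(OC)c3)c3ccccc3oc2=O)cc1`) gives 63500 nM, the only number available in this small set. Compound 2 (`COc1ccc(-c2c(Nc3cc(OC)c(OC)c(OC)c3)c3ccc(OC)cc3oc2=O)cc1`) has no single number to stand on, as the entry for compound 2 reads "not determined" (no result reported). The entry for compound 3 (`COc1ccc(-c2c(Nc3ccc(NC(C)=O)cc3)c3ccc(OC)cc3oc2=O)cc1`) likewise reads "not determined" (no result reported). Compound 4 (`COc1ccc(-c2c(Nc3cc(OC)c(OC)c(OC)c3)c3ccc(O)cc3oc2=O)cc1`) differs from compound 2 in one place, methoxy to hydroxy, on an oxygen on an aromatic ring: hydrogen in place of methyl on an oxygen on an aromatic ring. For the measured compounds named here, no measured step shows what this change does. Only a modest shift toward stronger inhibition in this assay is expected, perhaps none beyond the scatter, with the general level taken from compound 1 at 63500 nM. The estimated value for compound 4 is 30000 nM, with an expected range from 8000 nM to 100000 nM.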

Compound 4, half-maximal inhibitory concentration: 64200 nM
For compound 4 the middle estimate is 2.1-fold (0.33 log units) below the measured one, and the stated range covers the measured number.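

In this assay there is a 1.0-fold higher number from compound 1 to compound 4 (0.00 log units; within the scatter) as hydroxy takes the place of hydrogen on an aromatic carbon, so at this position on the shared core the two cannot be told apart in this read-out. The methoxy to hydroxy step, which would need a number for compound 2, cannot be read. Nothing available gives a reason for this result. The compounds shown leave open whether an amine, a carboxylic acid or a longer alkoxy chain at this position would stand apart from compound 1 and compound 4.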